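The source may report more compounds than this note shows. Statements on the series, on what has been measured and on what is new or still open speak of the compounds shown alone.

Compound 1 `O=C(CCCCC1CCSS1)NCc1cn(CCCOc2ccc3ccc(=O)oc3c2)nn1` and compound 2 `O=C(CCCCC1CCSS1)NCc1cn(CCCOc2ccc3cc(-c4ccccc4)c(=O)oc3c2)nn1` share one core and differ by a phenyl in place of hydrogen on an aromatic carbon. In a functional assay on PC-12 cells (Rattus norvegicus) for cytotoxicity, read by MTT assay, with stated times of 3 h and 2 h, tested at 0.1 uM (a higher number here means a stronger effect of the compound at the concentration tested, a lower number a weaker effect), compound 1 gives 37.8% and compound 2 gives 33.9%. Compound 2 thus stands within the scatter of the only other number shown. Compound 3 `O=C(CCCCC1CCSS1)NCc1cn(CCCOc2ccc3cc(-c4ccc(Cl)cc4)c(=O)oc3c2)nn1` carries chloro in place of hydrogen on an aromatic carbon. Among the compounds with values here, the one measured step that bears on this, a number 3.9 percentage points lower from compound 1 to compound 2 (within the scatter), stayed within the scatter, so in this assay no shift beyond the scatter is expected. Compound 3 is estimated at 34%, between 24% and 44%, which means an expected step of a number 0.1 percentage points higher from compound 2 to compound 3 (within the scatter).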

Compound 3, a percentage reported as activity, at one concentration (the size of the read-out at that concentration, not a potency): 40.9%
Compound 3: middle estimate off by 6.9 percentage points, on the low side, within the range that was stated.
By their numbers in this assay, from the lowest: compounds 2, 1 and 3 (each within the scatter of the next).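

In this assay, going from phenyl to 4-chlorophenyl, with chloro placed para to a large group, gives a number 7 percentage points higher from compound 2 to compound 3 (within the scatter). Measured against the hydrogen of compound 1, the whole 4-chlorophenyl group gives a number 3.1 percentage points higher from compound 1 to compound 3 (within the scatter), so this position has so far tolerated both changes without a shift beyond the scatter. No available measurement offers an explanation for these results. Still open, from the compounds shown here alone, is whether an amine or a carboxylic acid in place of the chloro would shift the read-out beyond the scatter.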